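The source may report more compounds than this note shows. Statements on the series, on what has been measured and on what is new or still open speak of the compounds shown alone.

Measured so far:
- compound 1, `COC(=O)Cn1cc(Nc2ncnc3ccc(-c4cnc(OC)c(NS(=O)(=O)c5ccc(F)cc5F)c4)cc23)cn1`: 1260 nM
- compound 2, `COC(=O)CCn1cc(Nc2ncnc3ccc(-c4cnc(OC)c(NS(C)(=O)=O)c4)cc23)cn1`: 970 nM

Two compounds carry numbers in a functional assay on HCT-116 cells (Homo sapiens) for antiproliferative activity, read by sulforhodamine B assay, with a stated time of 72 h; a lower number here means a stronger inhibitor, a higher number a weaker inhibitor. Compound 1, `COC(=O)Cn1cc(Nc2ncnc3ccc(-c4cnc(OC)c(NS(=O)(=O)c5ccc(F)cc5F)c4)cc23)cn1`, gives 1260 nM there, which is the higher of the two numbers; compound 2, `COC(=O)CCn1cc(Nc2ncnc3ccc(-c4cnc(OC)c(NS(C)(=O)=O)c4)cc23)cn1`, gives 970 nM, and the gap between these two values lies within the scatter, so the two compounds cannot be told apart on this evidence. Going by the values given here, no pair of compounds differing in a single place has been measured, so no single step has yet been sized in this assay.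

Compound 3, `COc1ncc(-c2ccc3ncnc(Nc4ccc(OCCO)nc4)c3c2)cc1NS(=O)(=O)c1ccc(F)cc1F`, has not been measured. It differs from compound 1 as follows: 6-(2-hydroxyethoxy)pyridin-3-yl in place of 1-((methoxycarbonyl)methyl)-1H-pyrazol-4-yl on a nitrogen on an aromatic ring. The shared core of compound 1 and its sulfonamide are kept; only the group on the amino nitrogen is exchanged. Among the compounds with values here, nothing among the measured pairs shows what such an exchange does in this assay, so any expectation rests on the structural change alone. He expects a small step toward a lower number, a 1.6-fold lower number from compound 1 to compound 3 (0.20 log units; within the scatter), with the direction uncertain. Compound 3 is estimated at 800 nM in this assay, within a range from 250 nM to 2500 nM.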

Compound 3, half-maximal inhibitory concentration: 2340 nM
For compound 3 the middle estimate is 2.9-fold (0.47 log units) below the measured one, and the stated range covers the measured number.
By their numbers in this assay, from the lowest: compounds 2, 1 and 3 (each within the scatter of the next, the first and the last beyond it).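

Going by these compounds alone, exchanging 1-((methoxycarbonyl)methyl)-1H-pyrazol-4-yl for 6-(2-hydroxyethoxy)pyridin-3-yl on a nitrogen on an aromatic ring gives the only single-place step available in this assay, a 1.9-fold higher number from compound 1 to compound 3 (0.27 log units; within the scatter). This shows that, with the shared core and the sulfonamide of compound 1 kept, a five-membered aromatic ring with 2 hetero atoms and a methyl ester chain can give way to a six-membered aromatic ring with 1 hetero atom and a hydroxyl-bearing chain without separating compound 3 from compound 1 in this assay. Nothing here accounts for this outcome, as no supporting measurement bears on it.

The compounds shown leave open whether the same exchange would read alike with the methanesulfonamide of compound 2 in place of the sulfonamide shared by compound 1 and compound 3. They also leave open what this assay would show with a carboxylic acid in place of the methyl ester on the pyrazole chain, or with a dimethylamino group in place of the hydroxyl at the end of the 2-hydroxyethoxy chain.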